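Acetylation of a Secondary Alcohol in an Antiproliferative Series

The compounds below may be only part of what the source reports. "The series", "measured", "known", "first", "only" and "open" are said of these compounds alone.

Compound 1 `C=C(C)CCC[C@]1(C)C2=CCC[C@](C)(C[C@H](OC(C)=O)C3=CC(=O)OC3O)[C@H]2CC[C@H]1C`: 3000 nM
Compound 2 `C=C(C)CC[C@]1(C)C2=CCC[C@](C)(C[C@@H](O)C3=CC(=O)OC3O)[C@H]2CC[C@H]1C`: 3300 nM
Compound 3 `C=C(C)CCC[C@]1(C)C2=CCC[C@](C)(C[C@H](O)C3=CC(=O)OC3O)[C@H]2CC[C@H]1C`: 3000 nM

Of the compounds shown here, three have been measured in a functional assay on HL-60 cells (Homo sapiens) for antiproliferative activity, read by XTT assay, with a stated time of 72 h (a higher number here means a weaker inhibitor, a lower number a stronger inhibitor), and all three values lie within the scatter of one another, so no order among them can be drawn. Compound 1 arises from compound 3 by acetyl in place of hydrogen on an oxygen on a saturated carbon. That step, no change at the digits printed from compound 3 to compound 1 (within the scatter), left the number where it stood. Compound 2 rests on a different core; how the core of compound 2 differs from the core of compound 3 is not broken down here, and their two values show no separation in this assay.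

Compound 4 `C=C(C)CC[C@]1(C)C2=CCC[C@](C)(C[C@@H](OC(C)=O)C3=CC(=O)OC3O)[C@H]2CC[C@H]1C` has not yet been measured. It differs from compound 2 by acetyl in place of hydrogen on an oxygen on a saturated carbon, the same change as that from compound 3 to compound 1, made at the same place. The step is expected to be small, no change at the digits printed from compound 2 to compound 4 (within the scatter), because no change at the digits printed from compound 3 to compound 1 (within the scatter) showed no movement for the same change on the other core. Compound 4 is therefore estimated at 3300 nM, with a likely range from 1600 nM to 7000 nM.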

Compound 4, half-maximal inhibitory concentration: 3300 nM
Compound 4: middle estimate and measured number agree at the digits printed, and the stated range covers the measured number.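

In this assay, acetyl in place of hydrogen on an oxygen on a saturated carbon gave no change at the digits printed from compound 2 to compound 4 (within the scatter). Set beside the earlier step, the change reads alike on both cores: the same change on two cores in this assay, no change at the digits printed (within the scatter) from compound 3 to compound 1 and no change at the digits printed (within the scatter) from compound 2 to compound 4, 1.0-fold (0.00 log units) apart, within the scatter of two such steps. Within these two pairs, hydroxy to acetoxy therefore carried from one core to the other with the same outcome, but this rests on only two pairs in a single cell assay, and it shows neither why the values stay level nor that the result would hold on a further core.

The compounds shown leave open whether a different group on that same oxygen, such as a methyl ether, a benzoyl ester or an ester with a longer chain, would read as the acetyl group does. They also leave open what happens on either core when the hydroxy group gives way to an amine or a fluorine.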